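From Trimethoxyphenyl to Chlorophenyl on One Aromatic Carbon

The source may report more compounds than this note shows. Statements on the series, on what has been measured and on what is new or still open speak of the compounds shown alone.

Compound 1 `CC1(C)O[C@H]2[C@H](OCc3noc(-c4ccc([N+](=O)[O-])cc4)n3)O[C@H](CO)[C@H]2O1` reaches only the assay limit, > 100000 nM, in a functional assay on T47D cells (Homo sapiens) for antiproliferative activity, read by sulforhodamine B assay, with a stated time of 48 h; a lower number here means a stronger inhibitor of growth, a higher number a weaker inhibitor of growth.
Compound 2 `COc1cc(-c2nc(CO[C@@H]3O[C@H](CSc4ncn[nH]4)[C@H]4OC5(CCCC5)O[C@@H]34)no2)cc(OC)c1OC` gives 44000 nM in this assay.
Compound 3 `COc1cc(-c2nc(CO[C@@H]3O[C@H](CSc4nnc(N)s4)[C@H]4OC5(CCCC5)O[C@@H]34)no2)cc(OC)c1OC` gives 42000 nM in this assay.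

Among the two numbers that are not limits, compound 2 has the higher one, but its nearest neighbour is compound 3, and that gap, a 1.0-fold lower number from compound 2 to compound 3 (0.02 log units; within the scatter), is within the scatter, so the two cannot be ordered. The value of compound 1 is a limit, not a number, and it tells only that the growth inhibition was too weak to measure: the limit of > 100000 nM in this assay, at which 1 of the 3 values shown sits.

Compound 4 `Clc1ccc(-c2nc(CO[C@@H]3O[C@H](CSc4ncn[nH]4)[C@H]4OC5(CCCC5)O[C@@H]34)no2)cc1` is the subject of the step from compound 2. The change is 4-chlorophenyl in place of 3,4,5-trimethoxyphenyl on an aromatic carbon. Among the compounds with values here, the only measured step, from compound 2 to compound 3, alters the group on the sulfur, not the aromatic carbon touched here, so it bears on this step only indirectly, showing that one change at a distant part of the shared core left the number unmoved. Within the data shown here, no measured pair shows what an exchange at this aromatic carbon does. The expectation for compound 4 is therefore cautious: a step of a 1.4-fold higher number from compound 2 to compound 4 (0.13 log units; within the scatter), that is, no change that clearly exceeds the scatter, with a wide allowance for a weaker inhibitor. The estimated value for compound 4 in this assay is 60000 nM, ranging from 20000 nM to 200000 nM.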

Compound 4, concentration for 50% growth inhibition: 10000 nM
Estimate against measurement, compound 4: 6.0-fold (0.78 log units) above; the whole stated range lies above it.
By their numbers in this assay, from the lowest: compound 4; then compounds 3 and 2 (each within the scatter of the next). At a limit, above all of these: compound 1.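

Within the data shown here, this exchange is the first measured change at this aromatic carbon of the five-membered aromatic ring, and in this assay it gives a step that the change on the sulfur did not: a 4.4-fold lower number from compound 2 to compound 4 (0.64 log units; beyond the scatter). The step is modest, but it shows that the number responds to the group at this position, and that the 3,4,5-trimethoxyphenyl group is not needed for growth inhibition in this small set, since 4-chlorophenyl gives the lower number. The exchange alters several things at once, removing three methoxy groups and adding a chlorine, and nothing measured here tells which of these accounts for the step.

Going by these compounds, it remains open whether the same exchange would lower the number when 5-amino-1,3,4-thiadiazol-2-yl, rather than 1H-1,2,4-triazol-5-yl, sits on the sulfur. Also open, on these data alone, is how plain phenyl, 4-fluorophenyl or 4-methoxyphenyl would compare at this aromatic carbon, which would help separate the effect of the chlorine from that of losing the methoxy groups.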